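The compounds below may be only part of what the source reports. "The series", "measured", "known", "first", "only" and "open" are said of these compounds alone.

Of the compounds shown here, three of one series have been tested in an ADME assay on microsomes from liver (Mus musculus) for metabolic stability, read by LC-MS, using NADPH, with stated times of 15 min and 60 min, tested at 4.6 uM; a lower number here means that the compound disappears faster, a higher number that the compound lasts longer. Compound 1 `CC(=O)N1CCC(c2ccc3c(c2)oc(=O)n3C(=O)NCCCCc2ccccc2)CC1` gives 1 h in this assay. Compound 2 `CC(C)CNC(=O)n1c(=O)oc2cc(C3CCCN(C)C3)ccc21` reaches > 1 h in this assay, which is a limit of the assay rather than a number. Compound 3 `CN1CCC(c2cc3oc(=O)n(C(=O)NCCCCc4ccccc4)c3cc2F)CC1` likewise reaches > 1 h in this assay, again a limit. Among the measured compounds shown here, compound 1 thus stands as the only compound with a numeric result, while the other two sit at the limit of > 1 h in this assay, at which 2 of the 3 values shown sit.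

Compound 4 `CN1CCN(c2ccc3c(c2)oc(=O)n3C(=O)NCCCCc2ccccc2)CC1=O` has not yet been tested in this assay. It differs from compound 1 in one place: 4-methyl-3-oxopiperazin-1-yl in place of 1-acetylpiperidin-4-yl on an aromatic carbon. Both the group that leaves and the group that enters are six-membered non-aromatic rings without hydrogen-bond donors and without net charge, so the shape and size of the molecule change little.

For the measured compounds named here, no pair of measured compounds differs in only one place, so no measured step can guide the expectation. With nothing in the measured values pointing either way, the step from compound 1 to compound 4 is expected to stay within the usual scatter, and no change at the digits printed from compound 1 to compound 4 (within the scatter) is the estimated change. Compound 4 is therefore expected to give 1 h in this assay, with a likely range from 0.5 h to 2 h.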

Compound 4, half-life: 0.5 h
Compound 4: the middle estimate sits 2.0-fold (0.30 log units) above what was measured, within the range that was stated.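

Among the compounds shown here, the exchange of 1-acetylpiperidin-4-yl for 4-methyl-3-oxopiperazin-1-yl on this aromatic carbon gives the first step in this assay that can be read as a comparison, and it is a 2.0-fold lower number from compound 1 to compound 4 (0.30 log units; within the scatter). Placing a second hetero atom in the six-membered ring and moving the carbonyl into that ring therefore produces no change that can be told apart from the ordinary spread of repeated measurements, although this single pair cannot show how far that finding extends. The remaining compounds add no readable step, and their results cannot be ranked against each other: the limit of > 1 h in this assay, at which 2 of the 4 values shown sit.

As far as these compounds go, it remains open whether a group of a different kind on this same aromatic carbon, such as a simple dimethylamino group, a carboxylic acid or a longer alkyl chain ending in an amine, would move the half-life beyond the scatter. From the compounds shown here alone, it is also open whether the same ring exchange would give a similar result with a different group on the other side of the shared core.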